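The source may report more compounds than this note shows. Statements on the series, on what has been measured and on what is new or still open speak of the compounds shown alone.

Compound 1, `CCN(C(=O)CC(CC(=O)NCCN1CCCC1)c1ccc(Cl)cc1)C1Cc2ccccc2C1`, in a functional assay on MCF7 cells (Homo sapiens) for inhibition (a lower number here means a stronger inhibitor, a higher number a weaker inhibitor), gives 20400 nM.
Compound 2, `CN(C(=O)CC(CC(=O)NCCN1CCCC1)c1ccc(Cl)cc1)C1Cc2ccccc2C1`, in this assay gives 76700 nM.
Compound 3, `CCN(CC)CCNC(=O)CC(CC(=O)N(CC)C1Cc2ccccc2C1)c1ccc(Cl)cc1`, in this assay gives 23000 nM.

The step of a 3.8-fold higher number from compound 1 to compound 2 (0.58 log units; beyond the scatter) goes with one change, (hydrogen in place of methyl on a saturated chain carbon bound to an amide-type nitrogen). The step of a 1.1-fold higher number from compound 1 to compound 3 (0.05 log units; within the scatter) goes with diethylamino in place of pyrrolidin-1-yl on a saturated chain carbon, two bonds along the chain from an amide-type nitrogen. Compound 4, `CCN(CC)CCNC(=O)CC(CC(=O)N(C)C1Cc2ccccc2C1)c1ccc(Cl)cc1`, has not been measured yet. It differs from compound 3 by hydrogen in place of methyl on a saturated chain carbon bound to an amide-type nitrogen, the same change that separates compound 1 from compound 2, and at the same place. Compound 3 and compound 4 share the core of compound 3, which differs from the core of compound 1 only by diethylamino in place of pyrrolidin-1-yl on a saturated chain carbon, two bonds along the chain from an amide-type nitrogen. Because a 3.8-fold higher number from compound 1 to compound 2 (0.58 log units; beyond the scatter) was modest, a similar step is expected here: a 3.7-fold higher number from compound 3 to compound 4 (0.57 log units; beyond the scatter). Compound 4 is therefore estimated to give 85000 nM in this assay, most likely between 40000 nM and 180000 nM.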

Compound 4, half-maximal inhibitory concentration: 28800 nM
Estimate against measurement, compound 4: 3.0-fold (0.47 log units) above; the whole stated range lies above it.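

In this assay, the step of a 1.3-fold higher number from compound 3 to compound 4 (0.10 log units; within the scatter) does not match the step seen on the pyrrolidin-1-yl core, so the ethyl to methyl change does not carry over unchanged from one core to the other: the same change on two cores in this assay, a 3.8-fold higher number (0.58 log units; beyond the scatter) from compound 1 to compound 2 and a 1.3-fold higher number (0.10 log units; within the scatter) from compound 3 to compound 4, 3.0-fold (0.48 log units) apart, beyond the scatter of two such steps. Read the other way, diethylamino in place of pyrrolidin-1-yl also depends on the core, with a 2.7-fold lower number from compound 2 to compound 4 (0.43 log units; beyond the scatter) on the methyl compounds: the same change on two cores in this assay, a 1.1-fold higher number (0.05 log units; within the scatter) from compound 1 to compound 3 and a 2.7-fold lower number (0.43 log units; beyond the scatter) from compound 2 to compound 4, 3.0-fold (0.48 log units) apart, beyond the scatter of two such steps. Both gaps rest on the same four compounds, so they are one result seen from two sides; it shows that the two changes do not act independently here, but not why, nor whether this holds on any other core.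

Still open, as far as these compounds go, is how a longer chain such as propyl in place of the ethyl, or a dimethylamino group in place of the diethylamino, would behave.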